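Cytotoxicity of three measured analogues and an expected fourth

The source may report more compounds than this note shows. Statements on the series, on what has been measured and on what is new or still open speak of the compounds shown alone.

compound 1 `Cc1ccccc1-c1nn(-c2ccccc2Cl)cc1CNCCN1CCN(C)CC1`: > 20000 nM
compound 2 `Cc1ccccc1-c1nn(-c2ccc(F)c(F)c2)cc1CNCCN1CCN(C)CC1`: > 20000 nM
compound 3 `Cc1ccc(-n2cc(CNCCN3CCN(C)CC3)c(-c3ccccc3C)n2)c(C)c1`: > 20000 nM

Three compounds share one core and differ only in the group on an aromatic nitrogen. In an ADME assay on Huh-7 cells (Homo sapiens) for cytotoxicity (a higher number here means that more compound is tolerated, a lower number that less compound is tolerated), compound 1 gives > 20000 nM, which is a limit of the assay. Compound 2 gives > 20000 nM, also a limit. Compound 3 gives > 20000 nM, again a limit. Because all three sit at the limit of > 20000 nM in this assay, at which 3 of the 3 values shown sit, the steps a step that the two limits leave unreadable from compound 1 to compound 2, a step that the two limits leave unreadable from compound 1 to compound 3 and a step that the two limits leave unreadable from compound 2 to compound 3 cannot be read. Compound 4 `Cc1ccccc1-c1nn(-c2ccc(C(F)(F)F)cc2)cc1CNCCN1CCN(C)CC1` differs from compound 3 by 4-(trifluoromethyl)phenyl in place of 2,4-dimethylphenyl on an aromatic nitrogen. For the measured compounds named here, no measured step bears on this change with a readable size, so no step beyond the scatter is expected. Compound 4 is therefore expected to give 20000 nM, in the range 10000 nM to 40000 nM. The expected step of a number no higher from compound 3 to compound 4 (the limit leaves the size open) is estimated as none beyond the scatter.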

Compound 4, half-maximal cytotoxic concentration: 11000 nM
The estimate for compound 4 lay 1.8-fold (0.26 log units) above the measured number, and the stated range covers the measured number.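

For the compounds shown here, with 4-(trifluoromethyl)phenyl on the aromatic nitrogen, compound 4 is the only compound of the four in this assay to give a number rather than a limit. The steps are an at least 1.8-fold lower number from compound 3 to compound 4 (0.25 log units; that floor lies within the scatter), an at least 1.8-fold lower number from compound 2 to compound 4 (0.25 log units; that floor lies within the scatter) and an at least 1.8-fold lower number from compound 1 to compound 4 (0.25 log units; that floor lies within the scatter), so none of them establishes a change at this position beyond the scatter. The steps among the other three compounds still cannot be read: the limit of > 20000 nM in this assay, at which 3 of the 4 values shown sit.

As far as these compounds go, how far the true numbers of those three compounds lie from that of compound 4 stays open. So does what an amine or a carboxylic acid in place of the trifluoromethyl group would give.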